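The source may hold more compounds than are shown below. What is called first, only, known or untested is meant among the compounds shown, and "the series" means these compounds.

Of the compounds shown here, two sharing one core have been measured so far. Compound 1 `O=[N+]([O-])c1ccc(-c2cc(-c3ccc(Br)cc3)n[nH]2)cc1` in a functional assay on AGS cells (Homo sapiens) for inhibition, read by MTT assay, with a stated time of 48 h (on this read-out lower numbers stand for stronger inhibition of growth and higher numbers for weaker inhibition of growth), gives 14600 nM. Compound 2 `COc1ccc(-c2cc(-c3ccccc3)n[nH]2)cc1` in this assay gives 11300 nM, the lower of the two numbers, although its gap to compound 1 lies within the usual scatter, so the two cannot be ranked against each other. Compound 3 `COc1ccc(-c2cc(-c3ccc(C(F)(F)F)cc3)n[nH]2)cc1` is the next structure in line. It differs from compound 2 by trifluoromethyl in place of hydrogen on an aromatic carbon. Among the compounds with values here, no measured pair shows what this kind of addition does on the shared core, so the only anchor is the value of compound 2 together with the closeness of compound 1 to it. The expected change is therefore modest, a 1.3-fold lower number from compound 2 to compound 3 (0.10 log units; within the scatter), with at most a slight lean toward stronger inhibition of growth. For compound 3 the estimate is 9000 nM, within a range from 3000 nM to 27000 nM.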

Compound 3, concentration for 50% growth inhibition: 14800 nM
The estimate for compound 3 lay 1.6-fold (0.22 log units) below the measured number; the measured number falls inside the stated range.
By their numbers in this assay, from the lowest: compounds 2, 1 and 3 (each within the scatter of the next).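

In this assay, placing trifluoromethyl in place of hydrogen on an aromatic carbon, para to a large group, gives a 1.3-fold higher number from compound 2 to compound 3 (0.12 log units; within the scatter). This is the first pair shown that differs in one place, and it shows that this position can carry trifluoromethyl without a difference that can be told from ordinary assay noise, so on this read-out compound 2 and compound 3 cannot be ranked. Nothing in the available data explains this result or links it to any property of the group.

What other kinds of group would do at this position remains open, since an amine, a carboxylic acid and a longer chain are not among the compounds shown. A single pair also leaves open whether trifluoromethyl would read the same way if the rest of the molecule were different.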